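A few compounds are considered here, and "the series" means these few. Any claim that something is new, unique, unknown or untested is made for them only; others in the source may bear on it.

Series in a functional assay on MCF7 cells (Homo sapiens) for inhibition, read by sulforhodamine B assay, with a stated time of 72 h; on this read-out higher numbers stand for weaker inhibition of growth and lower numbers for stronger inhibition of growth:
- compound 1 `NNC(=O)CCc1ccncc1-c1ccc2ccccc2c1`: > 10000 nM (a limit of the assay, not a number)
- compound 2 `CCOC(=O)/C=C/c1ccncc1-c1ccc2ccccc2c1`: 8320 nM
- compound 3 `COC(=O)/C=C/c1ccncc1-c1ccc2ccccc2c1`: 8170 nM

For the measured compounds named here, compound 3 stands level with compound 2, as the step of a 1.0-fold lower number from compound 2 to compound 3 (0.01 log units; within the scatter) shows, and these are the only two true numbers. Compound 4 `NC(=O)/C=C/c1ccncc1-c1ccc2ccccc2c1` is the next case, with the change (amino in place of methoxy on a carbonyl carbon), that is, amino in place of methoxy on a carbonyl carbon.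

Going by the values given here, two measured steps bear on this. Altering the ester alone gave a 1.0-fold lower number from compound 2 to compound 3 (0.01 log units; within the scatter). Among the compounds with values here, the only compound with nitrogen on the carbonyl is compound 1, and the step of an at least 1.2-fold lower number from compound 1 to compound 3 (0.08 log units; that floor lies within the scatter) also changes the chain, so it gives only a floor. Neither step points to a shift beyond the scatter in this assay, so none is expected. The expected change is a 1.1-fold higher number from compound 3 to compound 4 (0.04 log units; within the scatter). For compound 4 the estimated value is 9000 nM, with an expected range of 4000 nM to 16000 nM. A result at the limit of > 10000 nM in this assay, at which 1 of the 3 values shown sits, also remains possible.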

Compound 4, concentration for 50% growth inhibition: > 10000 nM
Compound 4 gave a limit, no number; the forecaster's own chance of this, stated with the estimate: 40%; middle value at least 1.1-fold (0.04 log units) away from the limit.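

In this assay compound 4 gives > 10000 nM, a limit of the assay and not a number, and this adds a second compound at that limit: the limit of > 10000 nM in this assay, at which 2 of the 4 values shown sit. With the 2-ethenyl chain kept, methoxycarbonyl to carbamoyl gives an at least 1.2-fold higher number from compound 3 to compound 4 (0.08 log units; that floor lies within the scatter), and the matching change from the ethyl ester gives an at least 1.2-fold higher number from compound 2 to compound 4 (0.07 log units; that floor lies within the scatter), so nitrogen on the carbonyl is now read without a change in the chain, though neither floor shows a shift beyond the scatter. The step between compound 1 and compound 4 cannot be read, with both values being limits.

Going by these compounds, the real size of the step from the esters to carbamoyl stays open, as only floors are available. Also open, on these data alone, is whether a carboxylic acid or a methylamide on this carbonyl carbon would give a number clearly apart from those of compound 2 and compound 3.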